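This account rests on a few compounds, and the source may have more. Where it says the series, first, only, none or still open, it means among the compounds named here.

Within the data shown here, compound 2 `CCCn1c(=O)[nH]c2nc(-c3ccc(S(=O)(=O)N4CCN(Cc5cccc(Br)c5)CC4)cc3)[nH]c2c1=O` gives 0.901 nM in an assay on CHO cells for displacement of a labelled ligand from adenosine receptor A2b (Mus musculus), read by scintillation counting, with a stated time of 75 min, in the presence of a further agent that is not named here (a lower number here means a stronger inhibitor, a higher number a weaker inhibitor), the highest of the two numbers measured so far. Its nearest neighbour is compound 1 `CCCn1c(=O)[nH]c2nc(-c3ccc(S(=O)(=O)N4CCN(c5ccc(Br)cc5)CC4)cc3)[nH]c2c1=O`, which in this assay gives 0.131 nM; the step of a 6.9-fold higher number from compound 1 to compound 2 (0.84 log units; beyond the scatter) shows how far compound 2 sits from it. The next compound, compound 3 `CCCn1c(=O)[nH]c2nc(-c3ccc(S(=O)(=O)N4CCN(c5cccc(F)c5)CC4)cc3)[nH]c2c1=O`, has not yet been measured. Compared with compound 2, the change is 3-fluorophenyl in place of 3-bromobenzyl on an amine nitrogen in a ring. Among the measured compounds shown here, only one measured step bears on this: the step of a 6.9-fold higher number from compound 1 to compound 2 (0.84 log units; beyond the scatter), where a group bound straight to the ring nitrogen was replaced by one bound through a benzyl carbon. Compound 3 returns to a group bound straight to that nitrogen, though with fluorine rather than bromine and on a different position of its ring. A step back down toward compound 1 is therefore expected, with a 3.6-fold lower number from compound 2 to compound 3 (0.56 log units; beyond the scatter) as the estimate. Compound 3 is expected to give about 0.25 nM, likely between 0.08 nM and 0.8 nM.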

Compound 3, inhibition constant: 0.926 nM
Compound 3: middle estimate off by 3.7-fold (0.57 log units), on the low side; the measured number lies above the stated range.
By their numbers in this assay, from the lowest: compound 1; then compounds 2 and 3 (each within the scatter of the next).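

In this assay, the step of a 1.0-fold higher number from compound 2 to compound 3 (0.01 log units; within the scatter) shows that a group bound straight to the ring nitrogen does not in itself give a lower number: the 3-fluorophenyl and 3-bromobenzyl groups cannot be told apart here. The step of a 7.1-fold higher number from compound 1 to compound 3 (0.85 log units; beyond the scatter) shows that, among these three compounds, the low number goes only with the 4-bromophenyl group of compound 1, not with every phenyl group bound directly to that nitrogen. No available evidence explains these differences.

The compounds shown leave open whether the halogen or its place on the phenyl ring matters more, as both change together between compound 1 and compound 3. A 3-bromophenyl or 4-fluorophenyl group on the same nitrogen would separate the two changes.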